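Branching the amide chain on an inactive core

The compounds below may be only part of what the source reports. "The series", "measured", "known", "first", "only" and "open" are said of these compounds alone.

Compound 1: `C=CC1=C(C(=O)NCCCCC)C(c2ccc(Cl)c(Cl)c2)OC1` — > 100000 nM
Compound 2: `C=CC1=C(C(=O)NCCC)C(c2ccc(Cl)c(Cl)c2)OC1` — > 100000 nM

Both measured compounds share one core and differ only in the chain on the amide nitrogen. In a functional assay on A549 cells (Homo sapiens) for cytotoxicity, read by MTT assay, with a stated time of 24 h (on this read-out higher numbers stand for weaker inhibition and lower numbers for stronger inhibition), compound 1 reaches only the limit of the assay, > 100000 nM, and not a number. In this assay compound 2 likewise sits at the limit, > 100000 nM, so no number is known for it either. The step that the two limits leave unreadable from compound 1 to compound 2 therefore cannot be read, since both ends are limits; what the two values show is that the limit of > 100000 nM in this assay, at which 2 of the 2 values shown sit, holds for every compound measured here.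

Compound 3, `C=CC1=C(C(=O)NCC(C)C)C(c2ccc(Cl)c(Cl)c2)OC1`, continues from compound 2 by methyl in place of hydrogen on a saturated chain carbon bound to two saturated chain carbons. Among the compounds with values here, the only measured step, the one from compound 1 to compound 2, gives no readable size, so there is nothing to point either way beyond the scatter. The step that the limit leaves unreadable from compound 2 to compound 3 is therefore expected to be none, with compound 3 most likely again at the limit. Compound 3 is estimated at 200000 nM, within a range from 100000 nM to 1000000 nM.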

Compound 3, half-maximal inhibitory concentration: > 100000 nM
Compound 3: no number, only a limit (the forecaster's own chance of this, stated with the estimate: 85%); the middle value is on the limit's open side.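

In this assay compound 3 gives > 100000 nM, a limit of the assay and not a number. Its steps from compound 1 and from compound 2 therefore cannot be read, and one limit covers the whole set: the limit of > 100000 nM in this assay, at which 3 of the 3 values shown sit. The compounds shown leave open whether any amide chain on the shared core gives a measurable value.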